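From 3-methylphenyl to 4-chlorophenyl in compound 3

The source may report more compounds than this note shows. Statements on the series, on what has been measured and on what is new or still open speak of the compounds shown alone.

In a functional assay on HT-29 cells (Homo sapiens) for antiproliferative activity, read by sulforhodamine B assay, with a stated time of 48 h (on this read-out higher numbers stand for weaker inhibition and lower numbers for stronger inhibition), compound 1 `Cc1cccc(OS(=O)(=O)c2ccc(N3CCN(C)C3=O)cc2)c1` gives 4300 nM. Compound 2 `CCCN1CCN(c2ccc(S(=O)(=O)Oc3c(Cl)cc(Cl)cc3Cl)cc2)C1=O` gives 56000 nM, and compound 3 `CCCN1CCN(c2ccc(S(=O)(=O)Oc3cccc(C)c3)cc2)C1=O` gives 65000 nM. Compound 2 and compound 3 are therefore level within the scatter, together at the weak end of these three numbers and well away from compound 1.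

Compound 4 `CCCN1CCN(c2ccc(S(=O)(=O)Oc3ccc(Cl)cc3)cc2)C1=O` differs from compound 3 in one place, with 4-chlorophenyl in place of 3-methylphenyl on an oxygen. The closest guide is a 1.2-fold higher number from compound 2 to compound 3 (0.06 log units; within the scatter), a change of group on that same oxygen that stays within the scatter. The large step of a 15-fold higher number from compound 1 to compound 3 (1.18 log units; beyond the scatter) comes from ethyl in place of hydrogen on a saturated chain carbon, a part that compound 4 leaves untouched, so it offers little guidance here. One step at this oxygen is thin evidence, but no shift beyond the scatter is expected in this assay.

The expected step is a 1.2-fold lower number from compound 3 to compound 4 (0.07 log units; within the scatter). For compound 4 the estimate is 55000 nM, with an expected range from 25000 nM to 120000 nM.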

Compound 4, half-maximal inhibitory concentration: 15000 nM
Compound 4: the middle estimate sits 3.7-fold (0.56 log units) above what was measured; the measured number lies below the stated range.
By their numbers in this assay, from the lowest: compound 1; then compound 4; then compounds 2 and 3 (each within the scatter of the next).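

Going by these compounds alone, the group on this oxygen matters more in this assay than the earlier compounds suggested. Within the data shown here, with 4-chlorophenyl in place of 3-methylphenyl there is a 4.3-fold lower number from compound 3 to compound 4 (0.64 log units; beyond the scatter) and with 4-chlorophenyl in place of 2,4,6-trichlorophenyl there is a 3.7-fold lower number from compound 2 to compound 4 (0.57 log units; beyond the scatter) so both of the other groups sit on the weak side of 4-chlorophenyl, although the only earlier change at this oxygen stayed within the scatter. Nothing available here explains why 4-chlorophenyl stands apart from the other two groups.

The compounds shown do not separate the chlorine from its place on the ring, which 3-chlorophenyl and 4-methylphenyl would help to do. On these data alone, it also remains open whether 4-chlorophenyl brings a similar step on the core of compound 1.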